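The compounds below may be only part of what the source reports. "The series", "measured", "known", "first", "only" and "open" are said of these compounds alone.

Of the compounds shown here, three have been measured in a physicochemical assay for solubility, in phosphate buffer, measured as kinetic solubility, with a stated time of 24 h, at pH 6.5; on this read-out higher numbers stand for higher solubility and lower numbers for lower solubility. Compound 1 (`CC(C)Oc1cc(Oc2ccc(S(C)(=O)=O)cc2)cc(-c2cccc(=O)[nH]2)c1`) gives 11000 nM. Compound 2 (`CC(C)Oc1cc(Oc2cnc(C(=O)N(C)C)cn2)cc(-c2nccc(=O)[nH]2)c1`) gives 373000 nM, and compound 3 (`CCC(CC)Oc1cc(Oc2cnc(C(=O)N(C)C)nc2)cc(-c2nccc(=O)[nH]2)c1`) gives 469000 nM. Compound 3 thus sits level with compound 2, within the usual scatter of repeated measurements, while compound 1 has a lower number, well beyond that scatter.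

Compound 4 (`C[C@@H](CO)Oc1cc(Oc2cnc(C(=O)N(C)C)nc2)cc(-c2nccc(=O)[nH]2)c1`) keeps the rest of compound 3 and changes one place: on an oxygen on an aromatic ring, 1-(hydroxymethyl)ethyl stands in place of pentan-3-yl (1-(hydroxymethyl)ethyl in place of pentan-3-yl on an oxygen on an aromatic ring). For the measured compounds named here, no two measured compounds differ in only one place, so no measured step shows what such a swap does. The only hint is a loose one: compound 2 at 373000 nM and compound 3 at 469000 nM carry different chains on that oxygen and differ elsewhere too, yet their values lie within the scatter. On this slim basis, no change beyond the scatter is expected in this assay. The expected step of a 1.1-fold higher number from compound 3 to compound 4 (0.03 log units; within the scatter) is a small one. Compound 4 is estimated at 500000 nM, with an expected range of 250000 nM to 1000000 nM.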

Compound 4, solubility: 339000 nM
Compound 4: the middle estimate sits 1.5-fold (0.17 log units) above what was measured; measured number inside the range.
By their numbers in this assay, from the lowest: compound 1; then compounds 4, 2 and 3 (each within the scatter of the next).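

In this assay, for the compounds shown here, the swap of pentan-3-yl for 1-(hydroxymethyl)ethyl on an oxygen on an aromatic ring gives a 1.4-fold lower number from compound 3 to compound 4 (0.14 log units; within the scatter), the first direct reading of a single change at this position. The read-out therefore treats the two compounds as level, even though the entering chain brings a hydrogen-bond donor and a defined stereocentre that the leaving chain lacks. Nothing at hand explains why these two different chains read alike.

On these data alone, it remains open whether another group on this oxygen, such as an amine, a carboxylic acid or a longer chain, would shift the number beyond the usual scatter. Also open, as far as these compounds go, are how the mirror-image form of 1-(hydroxymethyl)ethyl would read and whether the same swap would read alike on the core of compound 1.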